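Ester chain length and calcium channel inhibition

This account rests on a few compounds, and the source may have more. Where it says the series, first, only, none or still open, it means among the compounds named here.

Compound 2 `CCCOC(=O)C1=C(C)NC(C)=C(C(=O)OC)C1c1[nH]cnc1Cl` gives 437 nM in an assay on isolated protein for inhibition of Voltage-dependent L-type calcium channel subunit alpha-1C (Cavia porcellus) (a lower number here means a stronger inhibitor, a higher number a weaker inhibitor), the highest of the two numbers, while compound 1 `CCCOC(=O)C1=C(C)NC(C)=C(C(=O)OCCC)C1c1[nH]cnc1Cl` gives 63.1 nM. Compound 3 `CCCOC(=O)C1=C(C)NC(C)=C(C(=O)OCC)C1c1[nH]cnc1Cl` differs from compound 2 by methyl in place of hydrogen on a saturated chain carbon bound to an oxygen next to a carbonyl group. Among the measured compounds shown here, the one measured step that bears on this, a 6.9-fold higher number from compound 1 to compound 2 (0.84 log units; beyond the scatter), ran the other way on the same chain. A lengthening of that chain is therefore expected to lower the number for compound 3, by a step estimated as a 2.9-fold lower number from compound 2 to compound 3 (0.46 log units; beyond the scatter). The estimate for compound 3 is 150 nM, within a range from 60 nM to 400 nM.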

Compound 3, half-maximal inhibitory concentration: 407 nM
The estimate for compound 3 lay 2.7-fold (0.43 log units) below the measured number; the measured number lies above the stated range.
By their numbers in this assay, from the lowest: compound 1; then compounds 3 and 2 (each within the scatter of the next).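

On this ester chain, methyl in place of hydrogen gives a 1.1-fold lower number from compound 2 to compound 3 (0.03 log units; within the scatter), so in this assay the methoxycarbonyl and ethoxycarbonyl compounds are not told apart. The difference from compound 1 appears only with the further carbon, hydrogen in place of methyl on a saturated chain carbon, two bonds along the chain from an oxygen next to a carbonyl group, giving a 6.5-fold higher number from compound 1 to compound 3 (0.81 log units; beyond the scatter), so the number does not follow chain length evenly. Nothing on hand explains this. As far as these compounds go, whether a butyl or isopropyl ester would lower the number further remains open.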